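Swapping a Methoxyphenyl for a Nitrophenyl on a Chalcone

The compounds below may be only part of what the source reports. "The series", "measured", "known", "first", "only" and "open" are said of these compounds alone.

Compound 1, `O=C1OCC[C@@H]1NC(=S)SCCOc1ccc([N+](=O)[O-])cc1`: in a functional assay on MGC-803 cells (Homo sapiens) for antiproliferative activity, read by MTT assay, with a stated time of 72 h (on this read-out lower numbers stand for stronger inhibition and higher numbers for weaker inhibition), compound 1 gives > 100000 nM, which is a limit of the assay and not a number.
Compound 2, `COc1ccccc1/C=C/C(=O)c1ccc(OCC(=O)N[C@H]2CCOC2=O)cc1`: in this assay compound 2 gives 39400 nM.

Of the compounds shown here, two have been measured in this assay, and only one of them yields a number. Compound 1 sits at the limit (the limit of > 100000 nM in this assay, at which 1 of the 2 values shown sits), so its value says only that inhibition was too weak to be quantified. Compound 2 therefore stands as the only numeric result, with no other measured value to rank it against.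

Compound 3, `O=C(COc1ccc(C(=O)/C=C/c2cccc([N+](=O)[O-])c2)cc1)N[C@H]1CCOC1=O`, has not yet been measured. It keeps the whole core of compound 2 and differs in one place: 3-nitrophenyl in place of 2-methoxyphenyl on a double-bonded chain carbon bound to a double-bonded chain carbon. Going by the values given here, no measured pair in this set shares that kind of change, so there is no directly comparable step to lean on.

Compound 3 is expected to give 25000 nM, with a likely range from 8000 nM to 80000 nM. The expected step of a 1.6-fold lower number from compound 2 to compound 3 (0.20 log units; within the scatter) is small, within the usual scatter, leaning slightly toward stronger inhibition.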

Compound 3, half-maximal inhibitory concentration: > 64000 nM
Compound 3: a limit, no number (the forecaster's own chance of this, stated with the estimate: 10%); middle value at least 2.5-fold (0.40 log units) away from the limit.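

Compound 3 gives a limit and not a number in this assay: the limit of > 64000 nM in this assay, at which 1 of the 3 values shown sits.

Going by these compounds alone, this is the first reading of a change on the shared core: with 3-nitrophenyl in place of 2-methoxyphenyl on a double-bonded chain carbon bound to a double-bonded chain carbon, the read-out shows an at least 1.6-fold higher number from compound 2 to compound 3 (0.21 log units; that floor lies within the scatter). The step has a floor but no ceiling, and that floor lies within the usual scatter, so the true gap could be negligible or much larger; what the result does show is that this swap brings no measurable gain in inhibition of these cells.

The two compounds cannot tell whether the outcome follows from the arrival of 3-nitrophenyl or from the departure of 2-methoxyphenyl, and a single pair says nothing about how other groups would behave at this place. An unsubstituted phenyl ring, or a phenyl ring carrying an amine or a carboxylic acid, on the same chain carbon would be the next comparison, and a compound giving a true number would turn this open-ended step into a measured one.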